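Bicyclic heteroaryl swap on the urea nitrogen

A few compounds are considered here, and "the series" means these few. Any claim that something is new, unique, unknown or untested is made for them only; others in the source may bear on it.

Going by the values given here, compound 3 `O=C(Nc1noc2cnccc12)N1CCN(Cc2cccc(Oc3ccc(Cl)cc3)c2)CC1` gives 0.7 nM in an assay on isolated protein for inhibition of Fatty-acid amide hydrolase 1 (Rattus norvegicus), with a stated time of 60 min (a lower number here means a stronger inhibitor, a higher number a weaker inhibitor), and stands lowest of the three numbers so far. Compound 1 `O=C(Nc1cccc2nonc12)N1CCN(Cc2cccc(Oc3ccc(Cl)cc3)c2)CC1` gives 120 nM and compound 2 `O=C(Nc1cncc2ccccc12)N1CCN(Cc2cccc(Oc3ccc(Cl)cc3)c2)CC1` gives 8.3 nM; the steps of a 170-fold lower number from compound 1 to compound 3 (2.23 log units; beyond the scatter) and a 12-fold lower number from compound 2 to compound 3 (1.07 log units; beyond the scatter) both sit on the same amide-type nitrogen and were large. Compound 4 `O=C(Nc1cccn2ccnc12)N1CCN(Cc2cccc(Oc3ccc(Cl)cc3)c2)CC1` differs from compound 3 by a group of 9 heavy atoms (7 carbon, 2 nitrogen; one five-membered aromatic ring with 2 hetero atoms, one six-membered aromatic ring with 1 hetero atom) in place of a group of 9 heavy atoms (6 carbon, 2 nitrogen, 1 oxygen; one five-membered aromatic ring with 2 hetero atoms, one six-membered aromatic ring with 1 hetero atom), on an amide-type nitrogen, so one acceptor is lost. Both earlier steps at this position moved the number beyond the scatter, so a step beyond the scatter in this assay is expected here too, most likely upward, as compound 3 is the lowest point. Compound 4 is therefore estimated at 20 nM, range 3 nM to 150 nM, a step of a 29-fold higher number from compound 3 to compound 4 (1.46 log units; beyond the scatter).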

Compound 4, half-maximal inhibitory concentration: 3500 nM
Beside the measured number, compound 4's estimate is 180-fold (2.24 log units) below it; the whole stated range lies below it.
By their numbers in this assay, from the lowest: compound 3; then compound 2; then compound 1; then compound 4.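

In this assay, going by these compounds alone, this position spans a far wider range than the earlier compounds showed: a 5000-fold higher number from compound 3 to compound 4 (3.70 log units; beyond the scatter) exceeds every earlier step, although both groups hold one five-membered aromatic ring with 2 hetero atoms and one six-membered aromatic ring with 1 hetero atom. The new group also falls behind the other two, with a 420-fold higher number from compound 2 to compound 4 (2.62 log units; beyond the scatter) and a 29-fold higher number from compound 1 to compound 4 (1.46 log units; beyond the scatter), so these ring types alone do not set the number at this amide-type nitrogen. Nothing available explains the loss.

Going by these compounds, whether the ring oxygen or the arrangement of ring atoms carries the difference stays open. Where a single-ring group such as phenyl would fall in this order also stays open.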